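This account rests on a few compounds, and the source may have more. Where it says the series, first, only, none or still open, it means among the compounds named here.

Compound 1 `O=C1/C(=C\c2ccc(O)cc2)S/C(=N/c2ccccc2)N1Cc1ccncc1` gives 18900 nM in a functional assay on MCF7 cells (Homo sapiens) for cytotoxicity, read by MTT assay, with a stated time of 48 h; a lower number here means a stronger inhibitor, a higher number a weaker inhibitor. Compound 2 `COc1ccc(/C=C2/S/C(=N/c3ccccc3)N(Cc3ccncc3)C2=O)cc1` gives 31500 nM in this assay, and compound 3 `COc1ccc(/C=C2/S/C(=N/c3ccccc3)N(Cc3ccncc3)C2=O)cc1OC` gives 80700 nM in this assay, the highest of the three numbers. Compound 2 and compound 3 differ in their cores by methoxy in place of hydrogen on an aromatic carbon, a change that produced a 2.6-fold higher number from compound 2 to compound 3 (0.41 log units; beyond the scatter). Compound 4 `COc1cc(/C=C2/S/C(=N/c3ccccc3)N(Cc3ccncc3)C2=O)ccc1O` has not yet been measured in this assay. It differs from compound 3 by hydrogen in place of methyl on an oxygen on an aromatic ring. The same change, (hydrogen in place of methyl on an oxygen on an aromatic ring), is seen between measured compounds, where it gave a 1.7-fold lower number from compound 2 to compound 1 (0.22 log units; within the scatter). Because that step a 1.7-fold lower number from compound 2 to compound 1 (0.22 log units; within the scatter) was small, the step from compound 3 to compound 4 is expected to be of similar size, a 1.5-fold lower number from compound 3 to compound 4 (0.17 log units; within the scatter). Compound 4 is therefore estimated to give 55000 nM in this assay, most likely between 25000 nM and 120000 nM.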

Compound 4, half-maximal inhibitory concentration: 28000 nM
Compound 4: middle estimate off by 2.0-fold (0.29 log units), on the high side; low and high end bracket the measured number.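

Putting hydrogen in place of methyl on the oxygen gave a 2.9-fold lower number from compound 3 to compound 4 (0.46 log units; beyond the scatter), and this agrees with the same change on the other core: the same change on two cores in this assay, a 1.7-fold lower number (0.22 log units; within the scatter) from compound 2 to compound 1 and a 2.9-fold lower number (0.46 log units; beyond the scatter) from compound 3 to compound 4, 1.7-fold (0.24 log units) apart, within the scatter of two such steps
Methoxy in place of hydrogen gave a 1.5-fold higher number from compound 1 to compound 4 (0.17 log units; within the scatter), which likewise agrees with its earlier counterpart: the same change on two cores in this assay, a 2.6-fold higher number (0.41 log units; beyond the scatter) from compound 2 to compound 3 and a 1.5-fold higher number (0.17 log units; within the scatter) from compound 1 to compound 4, 1.7-fold (0.24 log units) apart, within the scatter of two such steps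
Each change therefore carried over between these two cores, and 4-hydroxy-3-methoxyphenyl in place of 4-methoxyphenyl gave a 1.1-fold lower number from compound 2 to compound 4 (0.05 log units; within the scatter), but two pairs per change cannot show that the same would hold on any further core.

The compounds shown leave open what a different group, such as an amine or a carboxylic acid, would do in place of the hydroxy group.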